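This account rests on a few compounds, and the source may have more. Where it says the series, first, only, none or still open, it means among the compounds named here.

Values in a functional assay on HBL-100 cells (Homo sapiens) for antiproliferative activity, read by sulforhodamine B assay, with a stated time of 48 h; on this read-out lower numbers stand for stronger inhibition of growth and higher numbers for weaker inhibition of growth:
- Compound 1 `CCC(C#CC(=O)OC)O/C=C/C(=O)OC`: 320 nM
- Compound 2 `COC(=O)C#CC(O/C=C/C(=O)OC)C1CCCCC1`: 2500 nM
- Compound 3 `COC(=O)C#CC(O/C=C/C(=O)OC)C1CC1`: 250 nM

Compound 3 gives 250 nM, level with compound 1 within the scatter, as a 1.3-fold lower number from compound 1 to compound 3 (0.11 log units; within the scatter) shows. Compound 2 stands apart, with a 10-fold lower number from compound 2 to compound 3 (1.00 log units; beyond the scatter).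

Compound 4 `COC(=O)C#CC(C)O/C=C/C(=O)OC` has methyl in place of cyclopropyl on a saturated chain carbon bound to an oxygen on an unsaturated carbon and a triple-bonded carbon.

The ethyl and cyclopropyl compounds match, while the cyclohexyl compound goes against any flat trend, with a 7.8-fold higher number from compound 1 to compound 2 (0.89 log units; beyond the scatter). Methyl itself is untested, so some uncertainty remains.

The step expected in this assay is small, a 1.4-fold higher number from compound 3 to compound 4 (0.15 log units; within the scatter), within the scatter.

The estimate for compound 4 is 350 nM, with an expected range of 120 nM to 1000 nM.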

Compound 4, concentration for 50% growth inhibition: 300 nM
Compound 4: middle estimate off by 1.2-fold (0.07 log units), on the high side, and the stated range covers the measured number.
By their numbers in this assay, from the lowest: compounds 3, 4 and 1 (each within the scatter of the next); then compound 2.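

In this assay, methyl in place of cyclopropyl leaves the number level (a 1.2-fold higher number from compound 3 to compound 4 (0.08 log units; within the scatter)), and the ethyl and methyl compounds also match (a 1.1-fold lower number from compound 1 to compound 4 (0.03 log units; within the scatter)), so methyl, ethyl and cyclopropyl now sit together at this position. Cyclohexyl remains the only group apart from them, also when set against methyl (an 8.3-fold lower number from compound 2 to compound 4 (0.92 log units; beyond the scatter)). No evidence here bears on the reason for that gap.

Still open, going by these compounds, is whether a longer chain such as butyl, or a cyclopentyl or phenyl group, stays with methyl or follows cyclohexyl. On these data alone, whether plain hydrogen at this position holds the same level is also open.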